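A few compounds are considered here, and "the series" means these few. Any claim that something is new, unique, unknown or untested is made for them only; others in the source may bear on it.

Of the compounds shown here, three have been measured so far in an assay for inhibition of Amine oxidase [flavin-containing] A (Rattus norvegicus); on this read-out lower numbers stand for stronger inhibition and higher numbers for weaker inhibition. Compound 1 , `COc1ccc(COc2ccc(-c3nn(CCC#N)c(=O)o3)cc2)cc1`, gives 16000 nM in this assay. Compound 2 , `Cc1cccc(COc2ccc(-c3nn(CCC#N)c(=O)o3)cc2)c1`, differs from compound 1 only by 3-methylphenyl in place of 4-methoxyphenyl on a saturated chain carbon bound to an oxygen on an aromatic ring. In this assay compound 2 gives 20000 nM, so the step of a 1.3-fold higher number from compound 1 to compound 2 (0.10 log units; within the scatter) leaves the two numbers within the scatter of each other. Compound 3 , `COc1ccc(COc2ccc(-c3nn(CCC#N)c(=S)o3)cc2)cc1`, carries a different core; the difference between the core of compound 1 and the core of compound 3 is not broken down here. In this assay compound 3 gives 4800 nM, the lowest of the three numbers, and its steps to compound 1 and to compound 2 both lie beyond the scatter.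

Compound 4 , `Cc1cccc(COc2ccc(-c3nn(CCC#N)c(=S)o3)cc2)c1`, has not yet been measured. It differs from compound 3 by 3-methylphenyl in place of 4-methoxyphenyl on a saturated chain carbon bound to an oxygen on an aromatic ring, and the place of this change is the same word for word as the place of the change from compound 1 to compound 2, so the same change appears two times among these compounds. The expected step from compound 3 to compound 4 is a 1.3-fold higher number from compound 3 to compound 4 (0.11 log units; within the scatter), about the size of a 1.3-fold higher number from compound 1 to compound 2 (0.10 log units; within the scatter), and rests on that earlier step being within the scatter. Compound 4 is therefore expected to give about 6200 nM in this assay, with a likely range from 3000 nM to 13000 nM.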

Compound 4, half-maximal inhibitory concentration: 14000 nM
The estimate for compound 4 lay 2.3-fold (0.35 log units) below the measured number; the measured number lies above the stated range.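

In this assay, placing 3-methylphenyl where 4-methoxyphenyl stood now gives a 2.9-fold higher number from compound 3 to compound 4 (0.46 log units; beyond the scatter). One step on one core lies within the scatter and the other step on the other core lies beyond it, which might suggest that the core changes the effect of the swap, but the gap between the two steps is itself within the scatter, so the data do not show that the change behaves differently on the two cores: the same change on two cores in this assay, a 1.3-fold higher number (0.10 log units; within the scatter) from compound 1 to compound 2 and a 2.9-fold higher number (0.46 log units; beyond the scatter) from compound 3 to compound 4, 2.3-fold (0.37 log units) apart, within the scatter of two such steps Nor do they prove that the change carries over unaltered, as a single pair on each core is too little to fix the true size of the step on either core, and the two steps could still turn out to differ once more pairs are available.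

As far as these compounds go, all four compounds carry one of just these two groups on the saturated chain carbon, so it remains open whether the comparison would hold for others there, such as plain phenyl or 4-chlorophenyl, or with an amine or a carboxylic acid in place of the nitrile. Also open, from the compounds shown here alone, is how the same swap reads on any other core or in any other assay.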